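Compound 1 to its methylcarbamoyl counterpart, compound 4

The compounds below may be only part of what the source reports. "The series", "measured", "known", "first", "only" and "open" are said of these compounds alone.

Compound 1 `Nc1nc2cc(-c3nn(CCCCCCCCCC(=O)NO)c4ncnc(N)c34)ccc2o1` reads > 50000 nM in a functional assay on SNU-423 cells (Homo sapiens) for inhibition, read by MTT assay, with a stated time of 72 h (a higher number here means a weaker inhibitor, a lower number a stronger inhibitor), and this is a limit of the assay, not a number. Compound 2 `Nc1ncnc2c1c(-c1cnc3[nH]ccc3c1)nn2CCCCCCCCCC(=O)NO` gives 8160 nM and compound 3 `Nc1ncnc2c1c(-c1cnc3[nH]ccc3c1)nn2CCCCCCC(=O)NO` gives 7500 nM, two values within the scatter of each other.

Compound 4 `CNC(=O)CCCCCCCn1nc(-c2ccc3oc(N)nc3c2)c2c(N)ncnc21` is not yet measured. Its structure has methylcarbamoyl in place of 2-(hydroxycarbamoyl)ethyl on a saturated chain carbon, seven bonds along the chain from an aromatic nitrogen.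

Among the compounds with values here, two measured steps bear on this change, both only in part. The step of a 1.1-fold lower number from compound 2 to compound 3 (0.04 log units; within the scatter) exchanges 3-(hydroxycarbamoyl)propyl for hydroxycarbamoyl and so keeps the end group while the chain changes. The step of an at least 6.1-fold lower number from compound 1 to compound 2 (0.78 log units; beyond the scatter) concerns the aromatic group on the core, and compound 4 keeps the group of compound 1, which stands at the limit of > 50000 nM in this assay, at which 1 of the 3 values shown sits. Within the data shown here, no measured step replaces hydroxycarbamoyl with methylcarbamoyl, so that part of the change has no measured size.

Resting on a 1.1-fold lower number from compound 2 to compound 3 (0.04 log units; within the scatter), no step beyond the scatter is expected in this assay, and the reading is expected to stay at the limit. The estimated change is a number no higher from compound 1 to compound 4 (the limit leaves the size open). Compound 4 is estimated at 50000 nM, with an expected range of 20000 nM to 100000 nM.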

Compound 4, half-maximal inhibitory concentration: 280 nM
The estimate for compound 4 lay 180-fold (2.25 log units) above the measured number; the whole stated range lies above it.
By their numbers in this assay, from the lowest: compound 4; then compounds 3 and 2 (each within the scatter of the next). At a limit, above all of these: compound 1.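

In this assay the chain end on the shared core turns out to be a position of large effect: methylcarbamoyl in place of 2-(hydroxycarbamoyl)ethyl, on a saturated chain carbon, seven bonds along the chain from an aromatic nitrogen, gives an at least 170-fold lower number from compound 1 to compound 4 (2.25 log units; beyond the scatter) and so moves the reading well beyond the scatter. Within the data shown here, the only earlier chain step, a 1.1-fold lower number from compound 2 to compound 3 (0.04 log units; within the scatter), kept the hydroxycarbamoyl end group, whereas compound 4 reaches 280 nM with no hydroxycarbamoyl at all, so that group is not required for a low number. Compound 1 stands at a limit of the assay, so the new step gives a bound and not an exact size: the limit of > 50000 nM in this assay, at which 1 of the 4 values shown sits.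

The step changes the end group and the chain length together, so the compounds shown do not divide its size between the two, and the aromatic group of compound 2 has not been seen with a methylcarbamoyl end. Going by these compounds, how a carboxylic acid or a primary carboxamide at the chain end would read, or a methylcarbamoyl on a longer chain, remains open.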